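Replacing an aryl group with an acetamide on the triazole nitrogen

A few compounds are considered here, and "the series" means these few. Any claim that something is new, unique, unknown or untested is made for them only; others in the source may bear on it.

Compound 1, `CCOC(=O)C1=Cc2ccccc2OC1(OCc1cn(-c2ccccc2)nn1)C(F)(F)F`: > 150000 nM
Compound 2, `CCOC(=O)C1=Cc2ccccc2OC1(OCc1cn(-c2ccc(F)c([N+](=O)[O-])c2)nn1)C(F)(F)F`: 13200 nM
Compound 3, `CCOC(=O)C1=Cc2ccccc2OC1(OCc1cn(-c2ccc(F)c(Cl)c2)nn1)C(F)(F)F`: 21500 nM

All three share the core of compound 1 and differ only in the group on the aromatic nitrogen of the triazole. In a functional assay on DU-145 cells (Homo sapiens) for inhibition, read by MTT assay, with a stated time of 24 h (on this read-out lower numbers stand for stronger inhibition and higher numbers for weaker inhibition), compound 1 gives > 150000 nM, which is a limit of the assay and not a number. Compound 2 gives 13200 nM in this assay. Compound 3 gives 21500 nM in this assay, the higher of the two numbers, with compound 2 closest to it (a 1.6-fold higher number from compound 2 to compound 3 (0.21 log units; within the scatter)). The two measured steps away from the bare phenyl are sizeable: an at least 11-fold lower number from compound 1 to compound 2 (1.05 log units; beyond the scatter) and an at least 6.9-fold lower number from compound 1 to compound 3 (0.84 log units; beyond the scatter).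

Compound 4, `CCOC(=O)C1=Cc2ccccc2OC1(OCc1cn(CC(=O)Nc2ccc(I)cc2Cl)nn1)C(F)(F)F`, differs from compound 3 in one place: ((2-chloro-4-iodophenyl)carbamoyl)methyl in place of 3-chloro-4-fluorophenyl on an aromatic nitrogen. Among the measured compounds shown here, no measured step changes the link between the aromatic nitrogen and the benzene ring, so none bears directly on this change. For the measured compounds named here, the two steps from compound 1 show only that a substituted benzene ring on that side lowers the number, and compound 4 keeps such a ring. The step is therefore expected to stay within the scatter: a 1.4-fold lower number from compound 3 to compound 4 (0.16 log units; within the scatter). Compound 4 is estimated at 15000 nM, between 4000 nM and 60000 nM.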

Compound 4, half-maximal inhibitory concentration: 24400 nM
Compound 4: the middle estimate sits 1.6-fold (0.21 log units) below what was measured; low and high end bracket the measured number.
By their numbers in this assay, from the lowest: compounds 2, 3 and 4 (each within the scatter of the next). At a limit, above all of these: compound 1.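

This step shows that the benzene ring need not sit directly on the triazole nitrogen: the ((2-chloro-4-iodophenyl)carbamoyl)methyl group, which is larger and adds one hydrogen-bond donor and one hydrogen-bond acceptor, is tolerated in place of 3-chloro-4-fluorophenyl, with a 1.1-fold higher number from compound 3 to compound 4 (0.05 log units; within the scatter) in this assay. The comparison with the nitro-bearing aryl group reads the same way, with a 1.8-fold higher number from compound 2 to compound 4 (0.27 log units; within the scatter), so this position accepts both directly attached aryl groups and the acetamide without a change that can be told from the scatter. The step from the bare phenyl, an at least 6.1-fold lower number from compound 1 to compound 4 (0.78 log units; beyond the scatter), shows that the acetamide also keeps the gain seen with the two substituted aryl groups, though it is read against a limit and not a number: the limit of > 150000 nM in this assay, at which 1 of the 4 values shown sits.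

Compound 4 changes the link and the halogens on the ring in a single step, so the compounds shown leave open how much each of the two contributes. An acetamide ending in an unsubstituted phenyl ring would address the halogens, and a benzyl group or a longer chain on the triazole nitrogen would address the link.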